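The compounds below may be only part of what the source reports. "The series", "measured", "known", "first", "only" and "open" are said of these compounds alone.

Measured so far:
compound 1 `COc1ccc(Cl)cc1C[C@@H]1CN/C(=N\O)CN(CC(=O)Nc2cccc(C(=O)O)c2)C1=O` — > 30000 nM
compound 2 `COc1ccc(Cl)cc1C[C@@H]1CNC(=O)CN(CC(=O)Nc2ccc(O)c(C(=O)O)c2)C1=O` — > 30000 nM
compound 3 `COc1ccc(Cl)cc1C[C@@H]1CN/C(=N\N(C)C)CN(CC(=O)Nc2cccc(S(C)(=O)=O)c2)C1=O` — 820 nM

In an assay on isolated protein for inhibition of kallikrein-7 (Homo sapiens), read by fluorescence, with stated times of 10 min and 30 min (a higher number here means a weaker inhibitor, a lower number a stronger inhibitor), compound 1 gives > 30000 nM, which is a limit of the assay and not a number. Compound 2 likewise returns only a limit, > 30000 nM. Compound 3 gives 820 nM. Among the compounds with values here, compound 1 therefore stands at the limit of > 30000 nM in this assay, at which 2 of the 3 values shown sit, and no measured step leads away from it within this set.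

Compound 4, `COc1ccc(Cl)cc1C[C@@H]1CN/C(=N\OCC(C)C)CN(CC(=O)Nc2cccc(C(=O)O)c2)C1=O`, differs from compound 1 by isobutyl in place of hydrogen on an oxygen. Within the data shown here, no measured pair shows this change, so its size cannot be read from the data; a gain beyond the scatter is possible but unsupported, and the estimated step of an at least 2.0-fold lower number from compound 1 to compound 4 (0.30 log units; that floor lies within the scatter) is kept small. Compound 4 is expected at 15000 nM, within 3000 nM to 30000 nM.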

Compound 4, half-maximal inhibitory concentration: > 30000 nM
Compound 4: no number, only a limit; the forecaster's own chance of this, stated with the estimate: 50%; middle value at least 2.0-fold (0.30 log units) away from the limit.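

Compound 1 and compound 4 both return only a limit and not a number, so no step between them can be read: the limit of > 30000 nM in this assay, at which 3 of the 4 values shown sit.

Whether isobutyl in place of hydrogen on an oxygen changes inhibition at all stays open in the compounds shown.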